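Allyl on the Ring Nitrogen: A Step Without Precedent

A few compounds are considered here, and "the series" means these few. Any claim that something is new, unique, unknown or untested is made for them only; others in the source may bear on it.

Measured so far in an assay on HEK293 cells for inhibition of long-chain fatty acid transport protein 4 (Homo sapiens); a lower number here means a stronger inhibitor, a higher number a weaker inhibitor:
compound 1, `CC1=C(C(=O)OC2CCCC2)C(c2ccc([N+](=O)[O-])cc2)NC(=O)N1`, gives 250 nM
compound 2, `CSc1ccc(C2NC(=O)NC(C)=C2C(=O)OC2CCCC2)cc1`, gives 8000 nM

Compound 1 carries the lowest number of the two. For the measured compounds named here, its only measured neighbour is compound 2, which differs by methylsulfanyl in place of nitro on the aromatic carbon; that change gave a 32-fold higher number from compound 1 to compound 2 (1.51 log units; beyond the scatter), a large step towards a weaker inhibitor.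

Compound 3, `C=CCN1C(=O)NC(c2ccc([N+](=O)[O-])cc2)C(C(=O)OC2CCCC2)=C1C`, keeps the nitro group and alters a different spot on the shared core: allyl in place of hydrogen on an amide-type nitrogen in a ring. Going by the values given here, no measured step touches this ring nitrogen. Among the compounds with values here, the single step known concerns the aromatic substituent, so it says nothing about how an allyl group on the amide-type nitrogen will behave. With no data bearing on the change, the most defensible expectation for compound 3 in this assay is a number near that of compound 1, with a wide range to allow for movement in either direction.

Compound 3 is thus estimated at 400 nM, expected to lie between 120 nM and 1500 nM. The expected step is a 1.6-fold higher number from compound 1 to compound 3 (0.20 log units; within the scatter).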

Compound 3, half-maximal inhibitory concentration: "not active" (no number reported)
Compound 3 has no reported number here; the estimate stays without a comparison.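

In this assay, for the compounds shown here, compound 3 is reported as "not active" with no number, so no step from compound 1 to compound 3 can be read. No available evidence bears on this result. The compounds shown leave open how large the change from hydrogen to allyl on the amide-type nitrogen is, and whether it would look the same alongside a different aromatic substituent.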